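Acetyl on a further oxygen, with limits only so far

The source may hold more compounds than are shown below. What is called first, only, known or untested is meant among the compounds shown, and "the series" means these compounds.

Compound 1 `C=C/C=C\[C@H](C)[C@H](OC(N)=O)[C@@H](C)[C@H](OC(C)=O)[C@@H](C)C/C(C)=C\[C@H](C)[C@@H](O)[C@@H](C)/C=C\[C@@H](O)C[C@@H]1OC(=O)C(C)=C[C@H]1C`: > 8100 nM (a limit)
Compound 2 `C=C/C=C\[C@H](C)[C@H](OC(N)=O)[C@@H](C)[C@H](OC(C)=O)[C@@H](C)C/C(C)=C\[C@H](C)[C@@H](OC(C)=O)[C@@H](C)/C=C\[C@@H](O)C[C@@H]1OC(=O)C(C)=C[C@H]1C`: > 7580 nM (a limit)

In a functional assay on A549 cells (Homo sapiens) for cytotoxicity (on this read-out higher numbers stand for weaker inhibition and lower numbers for stronger inhibition), compound 2 gives > 7580 nM, and this is a limit, not a number. In this assay compound 1 gives > 8100 nM, which is also a limit. Neither compound therefore has a numerical reading to serve as a starting point.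

Compound 3 `C=C/C=C\[C@H](C)[C@H](OC(N)=O)[C@@H](C)[C@H](OC(C)=O)[C@@H](C)C/C(C)=C\[C@H](C)[C@@H](OC(C)=O)[C@@H](C)/C=C\[C@H](C[C@@H]1OC(=O)C(C)=C[C@H]1C)OC(C)=O` departs from compound 2 by one change: acetyl in place of hydrogen on an oxygen on a saturated carbon. In words, this is hydroxy to acetoxy, with acetyl in place of hydrogen on an oxygen on a saturated carbon.

Within the data shown here, the only measured step of the same kind is a step that the two limits leave unreadable from compound 1 to compound 2. It gives neither a size nor a direction to carry over. With no numerical value in the series, no change beyond the scatter is expected, and a further limit is the likely outcome. The expected change in this assay is a step that the limit leaves unreadable from compound 2 to compound 3. The estimated value for compound 3 is 8500 nM, with an expected range from 3500 nM to 20000 nM.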

Compound 3, half-maximal inhibitory concentration: > 7130 nM
Compound 3 gave a limit, no number; the forecaster's own chance of this, stated with the estimate: 75%; the middle value lies beyond the limit too.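

In this assay, compound 2 and compound 3 both carry limits rather than numbers, so the step between them cannot be read. The compounds shown leave open whether acetyl in place of hydrogen on an oxygen on a saturated carbon changes the reading in this assay at all, and in which direction or by how much.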